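Replacing the chlorophenyl of compound 1 with an oxane ring

The compounds below may be only part of what the source reports. "The series", "measured", "known", "first", "only" and "open" are said of these compounds alone.

Compound 1 `C[C@@H](Nc1c(C(N)=O)cnc2ccc(-c3cccnc3)cc12)c1ccc(Cl)cc1`: 11 uL/min
Compound 2 `NC(=O)c1cnc2ccc(-c3cccnc3)cc2c1SC1CCCC1`: 18 uL/min
Compound 3 `NC(=O)c1cnc2ccc(-c3cccnc3)cc2c1NCC1CCCCC1`: 40 uL/min

Three compounds sharing one core were measured in an ADME assay on cells (Hepatocyte, Homo sapiens) for metabolic stability, with a stated time of 90 min; a higher number here means faster removal of the compound, a lower number slower removal. Compound 1 gives the lowest of the three numbers, with 11 uL/min; compound 2 sits within the scatter of it, while compound 3 lies clearly higher, since a 3.6-fold higher number from compound 1 to compound 3 (0.56 log units; beyond the scatter). The other measured step, a 2.2-fold higher number from compound 2 to compound 3 (0.35 log units; beyond the scatter), is also modest but beyond the scatter.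

Compound 4 `C[C@@H](Nc1c(C(N)=O)cnc2ccc(-c3cccnc3)cc12)C1CCOCC1` is not yet measured. It differs from compound 1 in one place: oxan-4-yl in place of 4-chlorophenyl on a saturated chain carbon bound to a nitrogen on an aromatic ring and a saturated chain carbon.

Neither measured step exchanges 4-chlorophenyl for oxan-4-yl, so none bears on it directly. The closest is the step from compound 1 to compound 3, in which a saturated ring entered at the same nitrogen and the number rose modestly. On that basis the number for compound 4 is expected to move upward if at all, with a change of about a 1.4-fold higher number from compound 1 to compound 4 (0.13 log units; within the scatter) expected, which may well stay within the scatter. The estimate for compound 4 is 15 uL/min, in a range from 7 uL/min to 32 uL/min.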

Compound 4, intrinsic clearance in a liver preparation (reported as CLH), per the amount of preparation that the assay uses: 14 uL/min
For compound 4 the middle estimate is 1.1-fold (0.03 log units) above the measured one, within the range that was stated.
By their numbers in this assay, from the lowest: compounds 1, 4 and 2 (each within the scatter of the next); then compound 3.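

In this assay, oxan-4-yl in place of 4-chlorophenyl on this saturated chain carbon gives a 1.3-fold higher number from compound 1 to compound 4 (0.10 log units; within the scatter) and so stays within the scatter, which shows that an aromatic ring of carbon only is not needed here to keep the number close to that of compound 1. A non-aromatic ring on the nitrogen side chain therefore does not in itself go with the higher number of compound 3: the printed step is a 2.9-fold lower number from compound 3 to compound 4 (0.46 log units; beyond the scatter) and lies beyond the scatter, whereas a 1.3-fold lower number from compound 2 to compound 4 (0.11 log units; within the scatter) lies within it. Nothing available gives a reason for any of these steps. Going by these compounds, the step between compound 3 and compound 4 changes both the ring and the chain, so the separate shares of the ring oxygen and the 1-substituted ethyl chain stay open. On these data alone, whether 1-cyclohexylethyl, a piperidine ring or a carboxylic acid on the ring would keep the number near that of compound 1 also stays open.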